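A few compounds are considered here, and "the series" means these few. Any claim that something is new, unique, unknown or untested is made for them only; others in the source may bear on it.

Working notes on the series. Compound 1 `CCCOC(=O)C1=C(C)NC(=O)NC1c1ccoc1`, compound 2 `CCCOC(=O)C1=C(C)NC(=O)NC1c1cccs1` and compound 3 `COC(=O)C1=C(C)NC(=S)NC1c1ccoc1` have been run in an assay on membranes from HeLa cells for displacement of a labelled ligand from adenosine receptor A3 (Homo sapiens), read by scintillation counting, with a stated time of 180 min, tested at 1 uM; on this read-out lower numbers stand for less inhibition and higher numbers for more inhibition at the one concentration tested (going by the name of the read-out); compound 4 `COC(=O)C1=C(C)NC(=S)NC1c1cccs1` has not. Compound 1 gives 11%, compound 2 gives 32%, and compound 3 gives 3%. Compound 3 and compound 1 lie within the scatter of each other, whereas compound 2 stands above compound 3 beyond it. Between compound 1 and compound 2 the only change is thiophen-2-yl in place of furan-3-yl on a saturated ring carbon, and that step is a number 21 percentage points higher from compound 1 to compound 2 (beyond the scatter). The same kind of change, (thiophen-2-yl in place of furan-3-yl on a saturated ring carbon), leads from compound 3 to compound 4; around the place it sits next to the ring atom that bears a methoxycarbonyl group rather than a propoxycarbonyl group. How the core of compound 3 differs from the core of compound 1 is not broken down here. For the measured compounds named here, with one such step on record, the next one is expected to be a number 15 percentage points higher from compound 3 to compound 4 (beyond the scatter), resting on the measured step of a number 21 percentage points higher from compound 1 to compound 2 (beyond the scatter), the only earlier instance of this change. Compound 4 is therefore estimated at 18% in this assay, between 2% and 38%.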

Compound 4, a percentage reported as inhibition, at one concentration (the size of the read-out at that concentration, not a potency): 1%
Estimate against measurement, compound 4: 17 percentage points above, outside the stated range (below it).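

On the core of compound 3, thiophen-2-yl in place of furan-3-yl gives a number 2 percentage points lower from compound 3 to compound 4 (within the scatter) in this assay, so the gain seen on the core of compound 1 does not reappear here. Set side by side, the two steps show that this change does not carry over with the same size from one core to the other: the same change on two cores in this assay, a number 21 percentage points higher (beyond the scatter) from compound 1 to compound 2 and a number 2 percentage points lower (within the scatter) from compound 3 to compound 4, 23 percentage points apart, beyond the scatter of two such steps. This shows that the step on the core of compound 1 is a poor guide for the core of compound 3, but it does not show which difference between the cores matters, the methoxycarbonyl group in place of the propoxycarbonyl group or the other difference, and two pairs set no rule for any further core.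

Open, on these data alone, is how the same change behaves on a core carrying an ethoxycarbonyl group or a carboxylic acid at that ring atom. Also open is whether furan-2-yl or thiophen-3-yl would follow either step, and readings at a single concentration give no potency for any of these compounds.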